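A Diester Replaces an Aryl Group on the Amide

A few compounds are considered here, and "the series" means these few. Any claim that something is new, unique, unknown or untested is made for them only; others in the source may bear on it.

Three amides sharing one core have been tested in a functional assay on HepG2 cells (Homo sapiens) for antiproliferative activity, read by MTT assay, with a stated time of 48 h; a higher number here means a weaker inhibitor, a lower number a stronger inhibitor. In this test, compound 1 (`CCn1c(C(=O)N(CCC#N)CCC#N)ccc1C(CC)(CC)c1ccc(OCCC(O)(CC)CC)c(C)c1`) gives 46300 nM. Compound 2 (`C=CCN(C)C(=O)c1ccc(C(CC)(CC)c2ccc(OCCC(O)(CC)CC)c(C)c2)n1CC`) gives > 50000 nM, which is a limit of the assay and not a number. Compound 3 (`CCn1c(C(=O)Nc2cccc(C(F)(F)F)c2)ccc1C(CC)(CC)c1ccc(OCCC(O)(CC)CC)c(C)c1`) gives > 50000 nM, which is also only a limit. Compound 3 therefore stands with compound 2 at the limit of > 50000 nM in this assay, at which 2 of the 3 values shown sit.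

Compound 4 (`CCOC(=O)C(CC(=O)OC)NC(=O)c1ccc(C(CC)(CC)c2ccc(OCCC(O)(CC)CC)c(C)c2)n1CC`) differs from compound 3 in one place, on an amide-type nitrogen: a group of 11 heavy atoms (7 carbon, 4 oxygen; no ring) in place of a group of 10 heavy atoms (7 carbon, 3 fluorine; one six-membered aromatic ring of carbon only), on an amide-type nitrogen.

The closest guides are changes made at the same amide. The first is an at least 1.0-fold higher number from compound 1 to compound 2 (0.03 log units; that floor lies within the scatter), and the second is an at least 1.0-fold higher number from compound 1 to compound 3 (0.03 log units; that floor lies within the scatter). The third, a step that the two limits leave unreadable from compound 2 to compound 3, adds no size. These floors give no sign of a gain in potency, so no step beyond the scatter is expected in this assay, in either direction.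

For compound 4, the expected value is 48000 nM, with an estimated range of 25000 nM to 90000 nM. The estimated change is an at least 1.0-fold lower number from compound 3 to compound 4 (0.01 log units; that floor lies within the scatter).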

Compound 4, half-maximal inhibitory concentration: > 50000 nM
Compound 4: a limit, no number; the forecaster's own chance of this, stated with the estimate: 60%; middle value at least 1.0-fold (0.01 log units) from the limit.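

Replacing the 3-(trifluoromethyl)phenyl group on the amide-type nitrogen with an open-chain diester gives no reading within the range of this assay: compound 4 gives > 50000 nM, which is a limit of the assay and not a number. Against the only amide here with a measured number, the result is an at least 1.0-fold higher number from compound 1 to compound 4 (0.03 log units; that floor lies within the scatter), while the steps that join two limits cannot be read. A ring-free group carrying hydrogen-bond acceptors therefore ends at the same limit as the aryl group and the allyl(methyl)amino group, so this change shows no sign of a gain: the limit of > 50000 nM in this assay, at which 3 of the 4 values shown sit.

How far apart compound 2, compound 3 and compound 4 truly lie stays hidden behind their limits. Also open, as far as these compounds go, is how a carboxylic acid in place of the esters, or an amine at the end of a longer chain, would read at this amide.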